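Swapping 2,4-difluorophenyl for 1H-indol-3-yl: what to expect

The source may report more compounds than this note shows. Statements on the series, on what has been measured and on what is new or still open speak of the compounds shown alone.

Compound 1 `COc1ccc(C=C2C(=O)N(c3ccc(Cl)cc3)N(c3ccc(Cl)cc3)C2=O)cc1` gives > 128000 nM as a limit
Compound 2 `O=C1C(=Cc2ccc(F)cc2F)C(=O)N(c2ccc(Cl)cc2)N1c1ccc(Cl)cc1` gives 22000 nM as a number

Going by the values given here, in a functional assay on MCF7 cells (Homo sapiens) for cytotoxicity, read by MTT assay, with a stated time of 72 h (a higher number here means a weaker inhibitor, a lower number a stronger inhibitor), compound 2 gives 22000 nM as the only actual number so far. For compound 1 the reading is a limit of the assay and not a number: > 128000 nM.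

Compound 3 `O=C1C(=Cc2c[nH]c3ccccc23)C(=O)N(c2ccc(Cl)cc2)N1c1ccc(Cl)cc1` has not yet been measured. It carries 1H-indol-3-yl in place of 2,4-difluorophenyl on a double-bonded chain carbon bound to a double-bonded ring carbon.

Among the compounds with values here, one measured step bears on this place: an at least 5.8-fold lower number from compound 1 to compound 2 (0.76 log units; beyond the scatter). As far as these compounds go, it came with 2,4-difluorophenyl in place of 4-methoxyphenyl and lies beyond the scatter, but one of its ends is a limit, so its full size remains unknown. That step shows that the group at this place can move the number, yet it does not involve 1H-indol-3-yl and gives no direction for the new change. No step beyond the scatter is therefore expected, although the uncertainty runs wide on both sides. The estimated step is a 1.4-fold higher number from compound 2 to compound 3 (0.13 log units; within the scatter) in this reading. For compound 3 the expected value is 30000 nM, with an estimated range of 8000 nM to 110000 nM.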

Compound 3, half-maximal inhibitory concentration: 34200 nM
Estimate against measurement, compound 3: 1.1-fold (0.06 log units) below; low and high end bracket the measured number.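

In this assay, the step to the indole is a 1.6-fold higher number from compound 2 to compound 3 (0.19 log units; within the scatter), so 2,4-difluorophenyl and 1H-indol-3-yl cannot be told apart at this place on a double-bonded chain carbon, even though 1H-indol-3-yl adds a five-membered aromatic ring with 1 hetero atom and 1 hydrogen-bond donor. The other new step, an at least 3.7-fold lower number from compound 1 to compound 3 (0.57 log units; beyond the scatter), shows that the earlier gain over 4-methoxyphenyl was not peculiar to 2,4-difluorophenyl, since a second group with no fluorine also lies beyond the scatter from compound 1. As far as these compounds go, the true size of that step stays unknown because the reading for compound 1 is a limit and not a number: the limit of > 128000 nM in this assay, at which 1 of the 3 values shown sits.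

The compounds shown leave open whether a plain phenyl, a 4-hydroxyphenyl or a pyridinyl group at this place would fall with 2,4-difluorophenyl and 1H-indol-3-yl or with 4-methoxyphenyl. They also leave open what an amine or a carboxylic acid on the aromatic ring would do to the number on the shared core.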